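The source may report more compounds than this note shows. Statements on the series, on what has been measured and on what is new or still open speak of the compounds shown alone.

In an ADME assay on HepG2 2.2.15 cells (Homo sapiens) for cytotoxicity (on this read-out lower numbers stand for higher toxicity in this test and higher numbers for lower toxicity in this test), compound 1 `O=C(OCCc1c(-c2ccccc2Cl)c2cc(Cl)ccc2[nH]c1=O)c1ccccc1` gives 43000 nM. Compound 2 `O=C(OCCc1c(-c2ccccc2Cl)c2cc(Cl)ccc2[nH]c1=O)c1cccs1` gives only a limit, > 1700000 nM, so its true position on this scale is not known. Compound 3 `O=C(CCOc1ccccc1)OCCc1c(-c2ccccc2Cl)c2cc(Cl)ccc2[nH]c1=O` carries 2-phenoxyethyl in place of thiophen-2-yl on a carbonyl carbon. Within the data shown here, the one measured step at this place is an at least 39-fold higher number from compound 1 to compound 2 (1.59 log units; beyond the scatter), large and beyond the scatter, with thiophen-2-yl in place of phenyl. Compound 3 again holds a six-membered aromatic ring of carbon only, as does compound 1 at 43000 nM, so a large step back towards lower numbers in this assay is expected. Among the measured compounds shown here, this rests on a single step, and the 2-phenoxyethyl group has no measured precedent. The expected change is an at least 11-fold lower number from compound 2 to compound 3 (1.05 log units; beyond the scatter), and another limit reading remains possible. Compound 3 is estimated at 150000 nM, with an expected range of 30000 nM to 800000 nM.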

Compound 3, half-maximal cytotoxic concentration: 46000 nM
Beside the measured number, compound 3's estimate is 3.3-fold (0.51 log units) above it; measured number inside the range.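

In this assay, 2-phenoxyethyl and phenyl on the carbonyl carbon cannot be told apart, although 2-phenoxyethyl holds more heavy atoms and an extra oxygen: a 1.1-fold higher number from compound 1 to compound 3 (0.03 log units; within the scatter). Among these three compounds, thiophen-2-yl is the only group that separates from the others, and the return from it to a six-membered aromatic ring of carbon only is large, with an at least 36-fold lower number from compound 2 to compound 3 (1.56 log units; beyond the scatter). Compound 2 gives a limit and not a number: the limit of > 1700000 nM in this assay, at which 1 of the 3 values shown sits.

On these data alone, the true size of the gap between compound 2 and the other two compounds stays open, as does whether it belongs to thiophen-2-yl alone or to five-membered aromatic rings in general. A furan-2-yl or a pyridin-3-yl group on the same carbonyl carbon would bear on that question.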